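A Change of Aryl Group in a Growth Assay

The source may hold more compounds than are shown below. What is called first, only, known or untested is meant among the compounds shown, and "the series" means these compounds.

Compound 1 `O=S(=O)(/C=C/c1ccccc1)Cc1ccc(Nc2ncnc3ccccc23)cc1`: > 100000 nM (a limit)
Compound 2 `O=S(=O)(/C=C/c1ccc(F)cc1Cl)Cc1ccc(Nc2ncnc3ccccc23)cc1`: 100000 nM

Going by the values given here, in a functional assay on UACC-62 cells (Homo sapiens) (a higher number here means a weaker inhibitor of growth, a lower number a stronger inhibitor of growth), compound 2 gives 100000 nM, the only actual number so far. Compound 1 stands at a limit, > 100000 nM. Compound 3 `O=S(=O)(/C=C/c1ccc(C(F)(F)F)cc1F)Cc1ccc(Nc2ncnc3ccccc23)cc1` differs from compound 2 at one place: 2-fluoro-4-(trifluoromethyl)phenyl in place of 2-chloro-4-fluorophenyl on a double-bonded chain carbon bound to a double-bonded chain carbon. Among the compounds with values here, the one measured step, a number no higher from compound 1 to compound 2 (the limit leaves the size open), changed the group at this same place, and its size cannot be read. No shift in either direction is therefore expected in this assay, and the expected change stays within the scatter: a 1.1-fold lower number from compound 2 to compound 3 (0.05 log units; within the scatter). Compound 3 is estimated at 90000 nM, with an expected range of 30000 nM to 150000 nM.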

Compound 3, concentration for 50% growth inhibition: 100000 nM
Compound 3: the middle estimate sits 1.1-fold (0.05 log units) below what was measured; the measured number falls inside the stated range.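

In this assay, 2-fluoro-4-(trifluoromethyl)phenyl in place of 2-chloro-4-fluorophenyl gives no change at the digits printed from compound 2 to compound 3 (within the scatter), so these two substituted phenyl groups on the double-bonded chain carbon read alike, which no earlier pair could show. 2-Fluoro-4-(trifluoromethyl)phenyl in place of phenyl gives a number no higher from compound 1 to compound 3 (the limit leaves the size open); this step and the earlier one with 2-chloro-4-fluorophenyl cannot be read because compound 1 stands at a limit: the limit of > 100000 nM in this assay, at which 1 of the 3 values shown sits.

On these data alone, it remains open whether a phenyl group carrying an amine or a carboxylic acid at this place, or a longer chain in place of the phenyl group, would give a lower number.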